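The source may hold more compounds than are shown below. What is called first, only, known or untested is meant among the compounds shown, and "the series" means these compounds.

This account follows a short series built on the shared core of compound 1 `Cc1cc(C)cc(OCCCCCn2ccc(=O)[nH]c2=O)c1`. In an ADME assay on HEL cells (Homo sapiens) for cytotoxicity, read by microscopy (a higher number here means that more compound is tolerated, a lower number that less compound is tolerated), compound 1 gives > 100000 nM, which is a limit of the assay and not a measured number. Compound 1 therefore stands at the limit of > 100000 nM in this assay, at which 1 of the 2 values shown sits, so only a bound, not a point value, is known for it. Compound 2 `CC(C)c1ccc(OCCCCCn2ccc(=O)[nH]c2=O)cc1` gives 100000 nM in this assay, a number rather than a limit. Compound 3 `Cc1cccc(OCCCCCn2ccc(=O)[nH]c2=O)c1` has not yet been measured; its structure differs from compound 1 by hydrogen in place of methyl on an aromatic carbon. The group that leaves is a methyl, the group that enters is a hydrogen, on an aromatic carbon of the six-membered aromatic ring of carbon only. With both measured compounds tolerated at high concentration, the step of a number no higher from compound 1 to compound 3 (the limit leaves the size open) is expected to be none beyond the scatter. Compound 3 is accordingly estimated at 100000 nM, with a range from 50000 nM to 200000 nM.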

Compound 3, minimum cytotoxic concentration: > 100000 nM
Compound 3: only a limit was reported; the forecaster's own chance of this, stated with the estimate: 60%; the middle value sits exactly at the limit.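

Going by these compounds alone, compound 1 and compound 3 both stop at a limit of the assay rather than a number, so no step between them can be read: the limit of > 100000 nM in this assay, at which 2 of the 3 values shown sit. The compounds shown leave open whether hydrogen in place of methyl on the aromatic carbon changes the tolerated concentration at all.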